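From compound 3 to compound 4: same atoms, rejoined

A few compounds are considered here, and "the series" means these few. Any claim that something is new, unique, unknown or untested is made for them only; others in the source may bear on it.

compound 1 `CS(=O)(=O)NCCCc1cn(-c2ccc(Br)cc2)nc1-c1ccc(Cl)cc1` gives < 5000 nM as a limit
compound 2 `CC(=O)NS(=O)(=O)CCc1cn(-c2ccc(Br)cc2)nc1-c1ccc(Cl)cc1` gives 165000 nM as a number
compound 3 `CS(=O)(=O)NC(=O)CCCc1cn(-c2ccc(Br)cc2)nc1-c1ccc(Cl)cc1` gives 135000 nM as a number

In a physicochemical assay for solubility, in phosphate buffer, measured as thermodynamic solubility, at pH 7.4 (a higher number here means a more soluble compound, a lower number a less soluble compound), compound 3 gives 135000 nM and compound 2 gives 165000 nM as numbers within the scatter of each other. Compound 1 has only a limit, < 5000 nM as reported.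

Compound 4 `CCS(=O)(=O)NC(=O)CCc1cn(-c2ccc(Br)cc2)nc1-c1ccc(Cl)cc1` has the same atoms as compound 3, joined differently: (ethylsulfonyl)carbamoyl in place of ((methylsulfonyl)carbamoyl)methyl on a saturated chain carbon, two bonds along the chain from an aromatic carbon with (ethylsulfonyl)carbamoyl in place of ((methylsulfonyl)carbamoyl)methyl on a saturated chain carbon, two bonds along the chain from an aromatic carbon.

Within the data shown here, the closest precedent is a 1.2-fold lower number from compound 2 to compound 3 (0.09 log units; within the scatter) which stays within the scatter. The steps of an at least 33-fold higher number from compound 1 to compound 2 (1.51 log units; beyond the scatter) and an at least 27-fold higher number from compound 1 to compound 3 (1.43 log units; beyond the scatter) are large, yet both start from the limit and replace the methanesulfonamido group of compound 1, a change not repeated here. The estimated change in this assay is a 1.0-fold lower number from compound 3 to compound 4 (0.02 log units; within the scatter) and so none beyond the scatter is expected. For compound 4 the expected value is 130000 nM with 60000 nM to 280000 nM as its estimated range.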

Compound 4, solubility: 10000 nM
Compound 4: the middle estimate sits 13-fold (1.11 log units) above what was measured, outside the stated range (below it).
By their numbers in this assay, from the lowest: compound 4; then compounds 3 and 2 (each within the scatter of the next). At a limit, below all of these: compound 1.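

In this assay, the rearrangement of the same atoms at this position was not neutral: the result is a 14-fold lower number from compound 3 to compound 4 (1.13 log units; beyond the scatter), and likewise a 17-fold lower number from compound 2 to compound 4 (1.22 log units; beyond the scatter). Among these compounds, compound 2 and compound 3 had stayed within the scatter of each other, so among the earlier compounds this end of the chain looked tolerant of rearrangement, whereas compound 4 shows that matching counts of atoms, donors and acceptors do not keep the number in place. Read against a limit, the remaining step is an at least 2.0-fold higher number from compound 1 to compound 4 (0.30 log units; that floor lies within the scatter), which leaves compound 4 not clearly separated from the lowest entry: the limit of < 5000 nM in this assay, at which 1 of the 4 values shown sits.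

The compounds shown leave open whether the drop follows the ethyl on the sulfonyl or the shorter chain to the carbonyl, as both change together in compound 4. They also leave open how a carboxylic acid or an amine at the end of this chain would read in this assay.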